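Two Sulfonamide Limits and a Third Methylphenyl Analogue

The compounds below may be only part of what the source reports. "The series", "measured", "known", "first", "only" and "open" are said of these compounds alone.

Compound 1, `Cc1ccc(S(=O)(=O)Nc2ccc(-c3nc4ccccc4o3)cc2)cc1`, gives in an assay on isolated protein for inhibition of malate dehydrogenase, mitochondrial (Sus scrofa), with stated times of 45 min and 30 min (a higher number here means a weaker inhibitor, a lower number a stronger inhibitor), the value > 63000 nM, which is a limit of the assay and not a number.
Compound 2, `O=S(=O)(Nc1ccc(-c2nc3ccccc3o2)cc1)c1ccccc1O`, gives in this assay the value > 63000 nM, likewise a limit of the assay.

Compound 2 therefore stands at the upper edge of what this assay can report, as the limit of > 63000 nM in this assay, at which 2 of the 2 values shown sit, shows. Going by the values given here, the one step measured so far, a step that the two limits leave unreadable from compound 1 to compound 2, cannot be read in size or direction, since both of its ends are limits.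

Compound 3, `Cc1cccc(S(=O)(=O)Nc2ccc(-c3nc4ccccc4o3)cc2)c1`, differs from compound 2 by 3-methylphenyl in place of 2-hydroxyphenyl on a sulfonyl sulfur. With no readable step to build on, and both known analogues sitting at the same limit, nothing in the data points to a change beyond the scatter. The step from compound 2 to compound 3 is expected to be a step that the limit leaves unreadable from compound 2 to compound 3. Compound 3 is therefore estimated at 100000 nM, most likely reported again only as a limit, within a range of 40000 nM to 300000 nM.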

Compound 3, half-maximal inhibitory concentration: > 63000 nM
Compound 3: a limit, no number (the forecaster's own chance of this, stated with the estimate: 85%); the middle value lies beyond the limit too.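

No new step can be read among compound 1, compound 2 and compound 3, since each value is a limit of the assay and not a number: the limit of > 63000 nM in this assay, at which 3 of the 3 values shown sit. The compounds shown leave open whether any group on the sulfonyl sulfur would give a readable value in this assay.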